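The source may report more compounds than this note shows. Statements on the series, on what has been measured and on what is new or still open speak of the compounds shown alone.

Measured so far:
compound 1, `COc1cc(-c2cc(/C=C/C(=O)c3ccc(N)cc3)[nH]n2)cc(OC)c1OC`, 50%
compound 2, `COc1ccc(C(=O)/C=C/c2cc(-c3cc(OC)c(OC)c(OC)c3)n[nH]2)cc1OC`, 45%

Both were tested in a functional assay on MDA-MB-468 cells (Homo sapiens) for cytotoxicity, read by sulforhodamine B assay, with a stated time of 48 h, tested at 1 uM; on this read-out lower numbers stand for a stronger effect and higher numbers for a weaker effect at the one concentration tested. Compound 2 gives 45%, the lowest of the two numbers shown, with compound 1 nearest at 50%; the gap between them is within the scatter, so the two cannot be told apart on this read-out. For the measured compounds named here, the one measured step, a number 5 percentage points lower from compound 1 to compound 2 (within the scatter), put a 3,4-dimethoxyphenyl in place of a 4-aminophenyl on a carbonyl carbon and stayed within the scatter.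

Compound 3, `COc1ccc(C(=O)/C=C/c2cc(-c3cc(OC)c(OC)c(OC)c3)n[nH]2)cc1`, is not yet measured. It differs from compound 2 in one place: hydrogen in place of methoxy on an aromatic carbon. Cut one bond further out, this reads 3,4-dimethoxyphenyl to 4-methoxyphenyl. Going by the values given here, no measured step removes a methoxy from this ring, and the only step available stayed within the scatter. Therefore no step beyond the scatter is expected here; the estimated step is a number 3 percentage points higher from compound 2 to compound 3 (within the scatter). Compound 3 is expected to give about 48% in this assay, within 30% to 70%.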

Compound 3, a percentage reported as activity, at one concentration (the size of the read-out at that concentration, not a potency): 68%
The estimate for compound 3 lay 20 percentage points below the measured number; the measured number falls inside the stated range.
By their numbers in this assay, from the lowest: compounds 2 and 1 (each within the scatter of the next); then compound 3.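

In this assay, for the compounds shown here, taking one methoxy off the 3,4-dimethoxyphenyl to leave 4-methoxyphenyl gives a number 23 percentage points higher from compound 2 to compound 3 (beyond the scatter), the first change here that clearly exceeds the scatter, and it weakens the effect at the one concentration tested. This ring therefore does respond to its substituents, which the earlier step could not show, and the second comparison points the same way: methoxy in place of amino on an aromatic carbon gives a number 18 percentage points higher from compound 1 to compound 3 (beyond the scatter). Since compound 1 and compound 2 cannot be told apart, two differently substituted rings give a similar effect while the ring with the single methoxy gives a weaker one, and nothing available explains this difference.

Going by these compounds, it remains open whether a hydroxy group, a chlorine atom or a dimethylamino group in place of the methoxy of compound 3 would restore the effect, and what a plain phenyl ring carrying no substituent would do. A reading at a single concentration also leaves open whether these compounds would keep the same order of stronger and weaker effect at other concentrations.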